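A few compounds are considered here, and "the series" means these few. Any claim that something is new, unique, unknown or untested is made for them only; others in the source may bear on it.

Measured so far:
compound 1 `COc1ccc(Cc2ccc(OC)c(OC)c2OC)cc1[N+](=O)[O-]` — 2900 nM
compound 2 `COc1ccc(Cc2cc(OC)c(OC)c(OC)c2)cc1O` — 440 nM

In a functional assay on HT-29 cells (Homo sapiens) for cytotoxicity, read by XTT assay, with a stated time of 72 h (on this read-out lower numbers stand for stronger inhibition and higher numbers for weaker inhibition), compound 1 gives 2900 nM, the highest of the two numbers shown. Compound 2 gives 440 nM in this assay, a lower number that lies beyond the usual scatter, so compound 1 stands as the weaker of the two measured compounds. For the measured compounds named here, no pair of measured compounds differs in a single place, so no step can be carried over to a new compound.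

Compound 3 `COc1ccc(Cc2ccc(OC)c(OC)c2OC)cc1N` is not yet measured. It differs from compound 1 in one place: amino in place of nitro on an aromatic carbon, sitting ortho to a methoxy group and meta to a large group. Going by the values given here, with no comparable step in the data, the expected change is a modest move toward a lower number, on the order of a 2.9-fold lower number from compound 1 to compound 3 (0.46 log units; beyond the scatter), though a result within the scatter would not surprise. For compound 3 in this assay the estimate is 1000 nM, within a range from 250 nM to 4000 nM.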

Compound 3, half-maximal inhibitory concentration: 330 nM
Compound 3: middle estimate off by 3.0-fold (0.48 log units), on the high side, and the stated range covers the measured number.
By their numbers in this assay, from the lowest: compounds 3 and 2 (each within the scatter of the next); then compound 1.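

In this assay, amino in place of nitro on an aromatic carbon ortho to a methoxy group gives an 8.8-fold lower number from compound 1 to compound 3 (0.94 log units; beyond the scatter), a step beyond the scatter and the first single-place change available in the series. The earlier compounds shown here differ in more than one place and could not isolate any one position; this pair shows that the read-out responds to the group on this carbon with the rest of the core of compound 1 unchanged. No measurement at hand speaks to what lies behind the step.

On these data alone, it remains open how other groups on this carbon, such as an acetamide or a dimethylamino group, would compare with the amino group of compound 3. Also open, as far as these compounds go, is whether the same exchange would give a similar step on the core of compound 2.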